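The compounds below may be only part of what the source reports. "The series", "measured", "known", "first", "only" and "open" are said of these compounds alone.

Of the compounds shown here, two have so far been tested in a functional assay on MDA-MB-231 cells for antagonist activity at C-X-C chemokine receptor type 4 (Homo sapiens), tested at 10 nM; a lower number here means a weaker effect, a higher number a stronger effect of the compound at the concentration tested. Compound 1, `c1cnc(NCc2ccc(CNc3ccccc3N3CCCC3)cc2)nc1`, gives 61% in this assay. Compound 2, `Clc1cccc(NCc2ccc(CNc3ncccn3)cc2)n1`, gives 100% in this assay and stands highest of the two numbers, with compound 1 as its nearest neighbour at a distance that lies beyond the usual scatter of repeated measurements.

The untested compound 3, `Clc1ccc(NCc2ccc(CNc3ncccn3)cc2)nc1`, is related to compound 2 by 5-chloropyridin-2-yl in place of 6-chloropyridin-2-yl on an amine nitrogen. The two hold the same atoms, joined differently, and the change is confined to the amine nitrogen whose other neighbour is a saturated chain carbon.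

For the measured compounds named here, no pair of measured compounds differs in one place, so there is no measured step from which the size of such a change could be read. Because compound 2 already gives 100% in this assay, little room remains above it. The step expected here is a number 10 percentage points lower from compound 2 to compound 3 (within the scatter), that is, none beyond the scatter, leaning if anything slightly downward. Compound 3 is therefore estimated to give 90% in this assay, within a range from 70% to 100%.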

Compound 3, a percentage reported as inhibition, at one concentration (the size of the read-out at that concentration, not a potency): 82%
Compound 3: the middle estimate sits 8 percentage points above what was measured; low and high end bracket the measured number.
By their numbers in this assay, from the lowest: compound 1; then compound 3; then compound 2.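

In this assay, for the compounds shown here, the exchange of 6-chloropyridin-2-yl for 5-chloropyridin-2-yl on the amine nitrogen whose other neighbour is a saturated chain carbon gives a number 18 percentage points lower from compound 2 to compound 3 (beyond the scatter) and is the first step that can be read. It shows that this place responds to the arrangement of the chloropyridin-2-yl group alone, since the two groups hold the same atoms and the same counted hydrogen-bond donors and acceptors, yet the effect is reduced rather than lost: compound 3 still gives 82% at the concentration tested. Nothing measured here accounts for the size or direction of this step.

From the compounds shown here alone, two arrangements of one group say little about the place as a whole, and how an unsubstituted pyridin-2-yl, a fluoropyridin-2-yl or a methoxypyridin-2-yl group would compare on the same amine nitrogen remains open. Going by these compounds alone, compound 1 differs from compound 2 and compound 3 in more than one place, so no step to it can be read, and what either chloropyridin-2-yl group would do in its setting also remains open.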